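This account rests on a few compounds, and the source may have more. Where it says the series, first, only, none or still open, it means among the compounds named here.

Within the data shown here, in an ADME assay on the whole organism for metabolic stability, with Rattus norvegicus as the target (on this read-out lower numbers stand for a shorter-lived compound and higher numbers for a longer-lived compound), three compounds have numbers so far. Compound 1 (`N[C@H]1C[C@@H](N2Cc3cnn(S(=O)(=O)C4CCCC4)c3C2)CO[C@@H]1c1cc(F)ccc1F`) gives 0.5 h and compound 2 (`N[C@H]1C[C@@H](N2Cc3cn(S(=O)(=O)C4CCCC4)nc3C2)CO[C@@H]1c1cc(F)ccc1F`) gives 1.5 h on this measure. Compound 3 (`CCC(=O)Nc1n[nH]c2c1CN([C@H]1CO[C@H](c3cc(F)ccc3F)[C@@H](N)C1)C2`) gives 2.2 h here, which places it within the scatter of compound 2 and beyond the scatter above compound 1. Compound 4 (`CCS(=O)(=O)Nc1n[nH]c2c1CN([C@H]1CO[C@H](c3cc(F)ccc3F)[C@@H](N)C1)C2`) differs from compound 3 in one place, with ethylsulfonyl in place of propanoyl on a nitrogen on an aromatic ring, so that propanoylamino becomes (ethylsulfonyl)amino. Among the measured compounds shown here, no measured pair shows this change, and the data hold no direct guide to its size. The expectation therefore starts from compound 3 and its 2.2 h alone. The expected step (a 1.2-fold lower number from compound 3 to compound 4 (0.06 log units; within the scatter)) is small and slightly downward, and it is not expected to go beyond the scatter. In this assay compound 4 is estimated at 1.9 h with an expected range of 0.9 h to 4.2 h for such a measurement.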

Compound 4, half-life: 2.1 h
Compound 4: the middle estimate sits 1.1-fold (0.04 log units) below what was measured; the measured number falls inside the stated range.
By their numbers in this assay, from the lowest: compound 1; then compounds 2, 4 and 3 (each within the scatter of the next).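

In this assay, replacing propanoyl with ethylsulfonyl on a nitrogen on an aromatic ring gives a step that stays within the scatter (a 1.0-fold lower number from compound 3 to compound 4 (0.02 log units; within the scatter)). Among these compounds, this is the first pair in the set that differs in one place, and it shows that this position accepts a group with 5 heavy atoms and 2 hydrogen-bond acceptors in place of one with 4 heavy atoms and 1 hydrogen-bond acceptor, with no readable change in half-life. Nothing available explains why the two groups read alike.

The compounds shown leave open whether a longer chain, a free amine or a carboxylic acid at this nitrogen would also leave the half-life in place. They also leave open whether the same exchange would read alike on a different core, since this single pair speaks only for the core of compound 3.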